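Chain Extension on a Fluoroalkoxy Side Chain

A few compounds are considered here, and "the series" means these few. Any claim that something is new, unique, unknown or untested is made for them only; others in the source may bear on it.

Measured compounds:
compound 1 `Fc1ccc(-c2cn([C@@H]3CN4CCC3CC4)nn2)cc1` — 3.09 nM
compound 2 `FCCOc1cccc(-c2cn([C@H]3CN4CCC3CC4)nn2)c1` — 558 nM

In an assay on HEK293 cells for displacement of a labelled ligand from Neuronal acetylcholine receptor; alpha3/beta4 (Homo sapiens), read by scintillation counting, with a stated time of 120 min (on this read-out lower numbers stand for stronger inhibition and higher numbers for weaker inhibition), compound 1 gives 3.09 nM, while compound 2 gives 558 nM. Of the two numbers, compound 2 stands at the higher one, and the gap to compound 1 lies well beyond the scatter of the measurement. The two compounds differ in more than one place, so their values can only be set side by side, not read as a single step.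

Compound 3 `FCCCOc1cccc(-c2cn([C@H]3CN4CCC3CC4)nn2)c1` is the next compound in the series. It differs from compound 2 in one place: fluoromethyl in place of fluoro on a saturated chain carbon, two bonds along the chain from an oxygen on an aromatic ring. The change lengthens the saturated chain by one carbon; the counted donors, acceptors and charge are unchanged.

Among the measured compounds shown here, no measured step of this kind exists among the compounds at hand, so the direction is uncertain. In this assay a modest step from compound 2 to compound 3 is expected, a 1.1-fold lower number from compound 2 to compound 3 (0.05 log units; within the scatter), within or near the scatter, in either direction. Compound 3 is therefore estimated at 500 nM, with a range from 150 nM to 1700 nM.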

Compound 3, inhibition constant: 1630 nM
Compound 3: the middle estimate sits 3.3-fold (0.51 log units) below what was measured; low and high end bracket the measured number.
By their numbers in this assay, from the lowest: compound 1; then compound 2; then compound 3.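

In this assay, lengthening the side chain from 2-fluoroethoxy to 3-fluoropropoxy gives a 2.9-fold higher number from compound 2 to compound 3 (0.47 log units; beyond the scatter), so this position responds to the change, and the response runs towards weaker inhibition. Of the compounds shown, this is the only pair that can be read as a single step: compound 1 differs from compound 2 in more than one place, and those values can only be set side by side. Nothing at hand bears on why the number rises with the longer chain.

On these data alone, a single step sets no trend, so it remains open whether a still longer chain, such as 4-fluorobutoxy, would continue in the same direction, and whether the fluorine itself matters, which a plain ethoxy or propoxy chain or a terminal hydroxyl would help to show. Also open, as far as these compounds go, is whether the same lengthening would count for as much on a compound closer to compound 1 , which stands at 3.09 nM in this assay, far from both fluoroalkoxy compounds.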